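The source may hold more compounds than are shown below. What is called first, only, known or untested is meant among the compounds shown, and "the series" means these compounds.

Of the compounds shown here, two have been tested so far. Compound 1 `Cn1ncc(Cl)c1-c1cc(C(=O)N[C@@H]2CN[C@H](CCO)C[C@H]2c2ccc(F)c(F)c2)oc1Cl` gives 460 nM in a functional assay on OVCAR-8 cells (Homo sapiens) for antiproliferative activity; on this read-out lower numbers stand for stronger inhibition and higher numbers for weaker inhibition. Compound 2 `Cn1ncc(Cl)c1-c1cc(C(=O)N[C@@H]2CN[C@H](CC(=O)NCC(O)CO)C[C@H]2c2ccc(Cl)c(Cl)c2)oc1Cl` carries a (2,3-dihydroxypropyl)carbamoyl group on a saturated chain carbon bound to a saturated ring carbon, together with a dichlorophenyl group in place of the difluorophenyl group of compound 1; in this assay compound 2 gives 5900 nM, the highest of the two numbers, and its nearest neighbour is compound 1, whose number lies beyond the usual scatter below it. Compound 1 and compound 2 differ in two places. Among the measured compounds shown here, the two values show only that the compound with the (2,3-dihydroxypropyl)carbamoyl group and the dichlorophenyl group is the weaker one here.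

Compound 3 `CCC[C@@H]1C[C@@H](c2ccc(Cl)c(Cl)c2)[C@H](NC(=O)c2cc(-c3c(Cl)cnn3C)c(Cl)o2)CN1` is the next candidate. It keeps the dichlorophenyl group of compound 2 and differs from it in a single place: ethyl in place of (2,3-dihydroxypropyl)carbamoyl on a saturated chain carbon bound to a saturated ring carbon. For the measured compounds named here, no step between measured compounds matches this change. Since compound 2 gives 5900 nM with that group in place, the step of a 5.9-fold lower number from compound 2 to compound 3 (0.77 log units; beyond the scatter) is expected to bring a lower number, larger than the scatter. Compound 3 is therefore estimated at 1000 nM, with a range from 300 nM to 4000 nM.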

Compound 3, half-maximal inhibitory concentration: 1620 nM
Beside the measured number, compound 3's estimate is 1.6-fold (0.21 log units) below it; measured number inside the range.
By their numbers in this assay, from the lowest: compound 1; then compound 3; then compound 2.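

In this assay, among the compounds shown here, ethyl in place of (2,3-dihydroxypropyl)carbamoyl on a saturated chain carbon bound to a saturated ring carbon gives a 3.6-fold lower number from compound 2 to compound 3 (0.56 log units; beyond the scatter), a modest step and the first comparison that changes this place alone, with the dichlorophenyl group and the rest of the core held constant. It therefore shows that this one change moves the number beyond the scatter, and that the number falls rather than rises when the hydrogen-bond donors and acceptors of the leaving group are absent from the ethyl that enters. No measurement at hand gives a reason for this step.

For the compounds shown here, the single step does not separate the carbonyl, the amide hydrogen and the hydroxyl groups of the leaving group, since all of them go at once, and it does not tell whether the same change would hold with the difluorophenyl group of compound 1. It also leaves open how a butyl chain, an amine or a carboxylic acid at this place would compare with ethyl.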